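Pyrazine-to-pyrimidine amide swap on two quinoline anilides

The source may report more compounds than this note shows. Statements on the series, on what has been measured and on what is new or still open speak of the compounds shown alone.

Compound 1 `Cc1ccc2cccc(NC(=O)c3cnccn3)c2n1` and compound 3 `Cc1ccc2cccc(NC(=O)c3ncccn3)c2n1` share one core; compound 2 `O=C(Nc1cc(F)cc2cccnc12)c1cnccn1` and compound 4 `O=C(Nc1cc(F)cc2cccnc12)c1ncccn1` share another. The difference between the two cores is not broken down here. In a functional assay on BXPC-3 cells (Homo sapiens) for inhibition, read by MTT assay, with a stated time of 72 h (a higher number here means a weaker inhibitor, a lower number a stronger inhibitor), compound 1 gives only the limit > 10000 nM. In this assay compound 3 likewise gives only the limit > 10000 nM. The change from compound 1 to compound 3 is pyrimidin-2-yl in place of pyrazin-2-yl on a carbonyl carbon, and the step it made, a step that the two limits leave unreadable from compound 1 to compound 3, cannot be read because of the limit of > 10000 nM in this assay, at which 3 of the 3 values shown sit. In this assay compound 2 also gives only the limit > 10000 nM. The change from compound 2 to compound 4 is pyrimidin-2-yl in place of pyrazin-2-yl on a carbonyl carbon, the same change at the same place. Compound 4 is not yet measured in this assay. With both measured ends of the first pair sitting at the limit, the expected step from compound 2 to compound 4 in this assay is a step that the limit leaves unreadable from compound 2 to compound 4, which rests only on the unreadable a step that the two limits leave unreadable from compound 1 to compound 3. Compound 4 is therefore expected to give about 20000 nM in this assay, most likely again reported as a limit, within 10000 nM to 100000 nM.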

Compound 4, half-maximal inhibitory concentration: > 10000 nM
Compound 4 ended at the assay's limit (the forecaster's own chance of this, stated with the estimate: 90%); the middle value is on the limit's open side.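

In this assay, compound 4 gives only a limit, as do compound 1, compound 2 and compound 3, so the step from compound 1 to compound 3 and the step from compound 2 to compound 4 cannot be read: the limit of > 10000 nM in this assay, at which 4 of the 4 values shown sit.

The compounds shown leave open whether pyrimidin-2-yl and pyrazin-2-yl on the carbonyl carbon differ at all in this assay.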